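Methyl in Place of Methoxy: Estimating Compound 4

The source may hold more compounds than are shown below. What is called first, only, known or untested is meant among the compounds shown, and "the series" means these compounds.

Compound 1 `COc1ccccc1N1CCN(CCCNc2ncccc2C(=O)N(C)C)CC1` is measured in a functional assay on aorta for antagonist activity at Alpha-1D adrenergic receptor (Rattus norvegicus) (on this read-out higher numbers stand for weaker binding and lower numbers for tighter binding), where compound 1 gives 20 nM. Compound 2 `Cc1ccccc1N1CCN(CCCNc2ncccc2C(=O)N(C)C)CC1` differs by methyl in place of methoxy on an aromatic carbon and gives 10 nM, a step of a 2.0-fold lower number from compound 1 to compound 2 (0.30 log units; within the scatter). Compound 3 `COc1ccc(N2CCN(CCCNc3ncccc3C(=O)N(C)C)CC2)c(OC)c1` carries the difference methoxy in place of hydrogen on an aromatic carbon and gives 1000 nM; the step of a 50-fold higher number from compound 1 to compound 3 (1.70 log units; beyond the scatter) is large, as is a 100-fold higher number from compound 2 to compound 3 (2.00 log units; beyond the scatter). Compound 4 `COc1cc(C)ccc1N1CCN(CCCNc2ncccc2C(=O)N(C)C)CC1` is not yet measured and differs from compound 3 by methyl in place of methoxy on an aromatic carbon. This is the same kind of change as from compound 1 to compound 2, but the place differs: there the group sits ortho to a large group, here meta to a methoxy group and para to a large group. The earlier step was within the scatter, yet a gain seems possible because a 50-fold higher number from compound 1 to compound 3 (1.70 log units; beyond the scatter) shows that adding methoxy at this place cost much; compound 4 is therefore expected to show a step of a 3.3-fold lower number from compound 3 to compound 4 (0.52 log units; beyond the scatter). Compound 4 is estimated at 300 nM, between 60 nM and 1500 nM.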

Compound 4, dissociation constant: 39.8 nM
Estimate against measurement, compound 4: 7.5-fold (0.88 log units) above, outside the stated range (below it).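

Methyl in place of methoxy does not carry over as one fixed step from one core to another in this assay: the same change on two cores in this assay, a 2.0-fold lower number (0.30 log units; within the scatter) from compound 1 to compound 2 and a 25-fold lower number (1.40 log units; beyond the scatter) from compound 3 to compound 4, 13-fold (1.10 log units) apart, beyond the scatter of two such steps

On the core of compound 3, the swap gives a 25-fold lower number from compound 3 to compound 4 (1.40 log units; beyond the scatter); set against the other compounds, the result reads a 2.0-fold higher number from compound 1 to compound 4 (0.30 log units; within the scatter) and a 4.0-fold higher number from compound 2 to compound 4 (0.60 log units; beyond the scatter). Two cores cannot show why the step changes size, nor how large it would be on a third core.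

On these data alone, whether an ethyl group or a chlorine atom at the place para to a large group would act like methyl remains open. Also open, as far as these compounds go, is whether a longer chain would alter the size of this step.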